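The source may report more compounds than this note shows. Statements on the series, on what has been measured and on what is new or still open speak of the compounds shown alone.

Three compounds of this series have numbers in a functional assay on HT-1080 cells (Homo sapiens) for inhibition, read by sulforhodamine B assay, with a stated time of 48 h; a lower number here means a stronger inhibitor, a higher number a weaker inhibitor. Compound 1 `CCNC(=O)Nc1ccc(/C=C\c2cccc(Cl)c2)cc1` gives 31000 nM. Compound 2 `CCNC(=O)Nc1ccc(/C=C/c2cc(OC)c(OC)c(OC)c2)cc1` gives 16000 nM; the difference between the cores of compound 1 and compound 2 is not broken down here, and the two values lie within the scatter of each other. Compound 3 `COc1cc(/C=C/c2ccc(N3CCNC3=O)cc2)cc(OC)c1OC` gives 400 nM in this assay, the lowest of the three numbers.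

Among the compounds with values here, the one counted step is a 40-fold lower number from compound 2 to compound 3 (1.60 log units; beyond the scatter), and it is 2-oxoimidazolidin-1-yl in place of (ethylcarbamoyl)amino on an aromatic carbon. Compound 4 `O=C1NCCN1c1ccc(/C=C\c2cccc(Cl)c2)cc1` has no number yet; it stands to compound 1 as 2-oxoimidazolidin-1-yl in place of (ethylcarbamoyl)amino on an aromatic carbon. The place is worded differently for the two pairs: in compound 2 the group sits para to a large group, in compound 1 para to a group of 9 heavy atoms, so this is the same kind of change rather than the same one. It occurs twice in all among these compounds.

The expectation for compound 4 rests on compound 2 alone, through a 40-fold lower number from compound 2 to compound 3 (1.60 log units; beyond the scatter), and on a core where the change has not been tried. The step from compound 1 to compound 4 is expected to be a 21-fold lower number from compound 1 to compound 4 (1.32 log units; beyond the scatter). Compound 4 is expected to give about 1500 nM in this assay, within a range from 300 nM to 8000 nM.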

Compound 4, half-maximal inhibitory concentration: 35 nM
Estimate against measurement, compound 4: 43-fold (1.63 log units) above, outside the stated range (below it).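

In this assay, 2-oxoimidazolidin-1-yl in place of (ethylcarbamoyl)amino on an aromatic carbon gives an 890-fold lower number from compound 1 to compound 4 (2.95 log units; beyond the scatter) and so lowers the number on both cores, but the size of the step does not carry over: the same change on two cores in this assay, a 40-fold lower number (1.60 log units; beyond the scatter) from compound 2 to compound 3 and an 890-fold lower number (2.95 log units; beyond the scatter) from compound 1 to compound 4, 22-fold (1.35 log units) apart, beyond the scatter of two such steps. The direction is therefore shared by these two pairs, while a step measured on one core did not give the size of the step on the other. Two pairs do not establish a rule for the series, and the difference between the core of compound 1 and the core of compound 2 is not broken down, so the data do not show which part of it goes with the larger step.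

The compounds shown leave open whether the same change would lower the number on further cores. They also leave open how a methyl group on the ring nitrogen of the 2-oxoimidazolidin-1-yl group, or a propyl chain in place of the ethyl chain of the open group, would read in this assay.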